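The source may hold more compounds than are shown below. What is called first, only, known or untested is meant among the compounds shown, and "the series" means these compounds.

In a functional assay on Huh-7 cells (Homo sapiens) for antiproliferative activity, with a stated time of 48 h (a higher number here means a weaker inhibitor, a lower number a stronger inhibitor), compound 1 `CCOC(=O)c1ccc(-c2ccc(N(CC)CC)nn2)cc1` gives 9000 nM. As far as these compounds go, compound 2 `CCOC(=O)c1ccc(-c2ccc(OC(C)C)nn2)cc1` reads > 25000 nM, which is a limit of the assay and not a number, so its true standing is unknown. Compound 3 `CCCCOc1ccc(-c2ccc(C(=O)OCC)cc2)nn1` differs from it by butyl in place of isopropyl on an oxygen on an aromatic ring. Within the data shown here, the only measured step bearing on this is an at least 2.7-fold higher number from compound 1 to compound 2 (0.44 log units; beyond the scatter), which replaced diethylamino with isopropoxy and left the chain on the oxygen untested. It therefore gives only weak guidance, and little change beyond the scatter is expected in this assay. The expected move is an at least 1.2-fold lower number from compound 2 to compound 3 (0.09 log units; that floor lies within the scatter). Compound 3 is estimated at 20000 nM, with an expected range of 8000 nM to 50000 nM.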

Compound 3, half-maximal inhibitory concentration: > 25000 nM
Compound 3 ended at the assay's limit (the forecaster's own chance of this, stated with the estimate: 50%); middle value at least 1.2-fold (0.09 log units) from the limit.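

In this assay compound 3 reads > 25000 nM, which is a limit of the assay and not a number. Butoxy in place of diethylamino gives an at least 2.7-fold higher number from compound 1 to compound 3 (0.44 log units; beyond the scatter), so a second alkoxy chain on this aromatic carbon also stands apart from the diethylamino compound. The step between the two alkoxy compounds cannot be read: the limit of > 25000 nM in this assay, at which 2 of the 3 values shown sit.

As far as these compounds go, whether isopropoxy and butoxy differ at all stays open. Also open, from the compounds shown here alone, is whether another amine on this carbon, such as dimethylamino or pyrrolidine, would match or improve on compound 1 at 9000 nM.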